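Swapping a Butyl Chain for Cyclopropyl at the Amine

A few compounds are considered here, and "the series" means these few. Any claim that something is new, unique, unknown or untested is made for them only; others in the source may bear on it.

Compound 3 `CCCCNc1nc(-c2ccccc2)nc2c1nnn2Cc1ccccc1F` carries a butyl group on a nitrogen on an aromatic ring. In an assay on isolated protein for binding affinity to adenosine receptor A1 (Bos taurus) (on this read-out lower numbers stand for stronger inhibition and higher numbers for weaker inhibition), compound 3 gives 4300000 nM, the second highest of three numbers. Compound 2 `OC1CCC(Nc2nc(-c3ccccc3)nc3c2nnn3Cc2ccccc2F)CC1` gives 1850000 nM, and the step between them is a 2.3-fold higher number from compound 2 to compound 3 (0.37 log units; beyond the scatter). Compound 1 `COc1ccc(C(=O)Nc2nc(-c3ccccc3)nc3c2nnn3Cc2ccccc2F)cc1` gives 21900000 nM; the step of a 5.1-fold lower number from compound 1 to compound 3 (0.71 log units; beyond the scatter) and the step of a 12-fold lower number from compound 1 to compound 2 (1.07 log units; beyond the scatter) both show compound 1 as the weakest binder here. Compound 4 `Fc1ccccc1Cn1nnc2c(NC3CC3)nc(-c3ccccc3)nc21` differs from compound 3 in one place: cyclopropyl in place of butyl on a nitrogen on an aromatic ring. All three measured steps change the group on this same nitrogen, yet only those leaving compound 1 were large; between the two small groups of compound 2 and compound 3 the step was modest. The expected step is a 1.2-fold lower number from compound 3 to compound 4 (0.09 log units; within the scatter), probably inside the scatter. Compound 4 is therefore estimated at 3500000 nM, within 1000000 nM to 12000000 nM.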

Compound 4, inhibition constant: 15000000 nM
Compound 4: the middle estimate sits 4.3-fold (0.63 log units) below what was measured; measured number above the stated range.
By their numbers in this assay, from the lowest: compound 2; then compound 3; then compounds 4 and 1 (each within the scatter of the next).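

At this nitrogen, a 3.5-fold higher number from compound 3 to compound 4 (0.54 log units; beyond the scatter) shows that even cyclopropyl in place of butyl, a change of one carbon and a ring, moves the number beyond the scatter. Against the 4-hydroxycyclohexyl group the gap widens, with an 8.1-fold higher number from compound 2 to compound 4 (0.91 log units; beyond the scatter) on the same nitrogen. Against the (4-methoxyphenyl)carbonyl group, a 1.5-fold lower number from compound 1 to compound 4 (0.16 log units; within the scatter) leaves no readable difference, so compound 1 no longer stands alone at the weak end.

Going by these compounds, how a cyclobutyl group or a longer chain such as hexyl would read on this nitrogen stays open. Nothing shown explains the gap between the butyl and cyclopropyl groups.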